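The source may report more compounds than this note shows. Statements on the series, on what has been measured and on what is new or still open speak of the compounds shown alone.

Measured compounds:
Compound 1 `COC(=O)N1C[C@@H](C)N(c2ncc3[nH]nc(-c4ccc(N5CCN(C)CC5)cc4)c3n2)[C@@H](C)C1`: in an assay on Sf9 cells for inhibition of activin receptor type-1 (Homo sapiens), read by HTRF, with a stated time of 3 h, in the presence of a further agent that is not named here (a lower number here means a stronger inhibitor, a higher number a weaker inhibitor), compound 1 gives 0.98 nM.
Compound 2 `C[C@@H]1CN(c2ccc(-c3n[nH]c4cnc(N5[C@H](C)COC[C@@H]5C)nc34)cn2)CCN1`: in this assay compound 2 gives 23 nM.
Compound 3 `C[C@@H]1CN(c2ccc(-c3n[nH]c4ccc(N5CCCCC5)nc34)cn2)CCN1`: in this assay compound 3 gives 95 nM.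

Among these three numbers compound 2 holds the second highest. Its nearest neighbour is compound 3, whose number is higher by a margin that lies beyond the usual scatter; the furthest is compound 1, whose number is lower by a margin that also lies beyond the scatter. Among the measured compounds shown here, none of the three pairs differs in one place only, so no single-change step is available from the measured set.

Compound 4 `C[C@@H]1CN(c2ccc(-c3n[nH]c4cnc(N5[C@H](C)CNC[C@@H]5C)nc34)cn2)CCN1` is the unmeasured partner of compound 2. The change is 2,6-dimethylpiperazin-1-yl in place of 3,5-dimethylmorpholin-4-yl on an aromatic carbon. Both groups carry two defined stereocentres and sit on the same aromatic carbon between two ring nitrogen atoms; the oxygen of the morpholine gives way to a ring nitrogen that adds one hydrogen-bond donor.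

For the measured compounds named here, with no comparable step measured here, only a modest shift is expected, in either direction, and most likely one not beyond the scatter. For compound 4 in this assay the estimate is 20 nM, in the range 5 nM to 80 nM, which means an expected step of a 1.2-fold lower number from compound 2 to compound 4 (0.06 log units; within the scatter).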

Compound 4, half-maximal inhibitory concentration: 793 nM
Compound 4: middle estimate off by 40-fold (1.60 log units), on the low side; the whole stated range lies below it.
By their numbers in this assay, from the lowest: compound 1; then compound 2; then compound 3; then compound 4.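

In this assay the placing of 2,6-dimethylpiperazin-1-yl where 3,5-dimethylmorpholin-4-yl stood gives a 34-fold higher number from compound 2 to compound 4 (1.54 log units; beyond the scatter) and so shows that this aromatic carbon between two ring nitrogen atoms is highly sensitive to the identity of its substituent. The earlier compounds shown here could not show this, since no two of them differed in one place only; here the heavy-atom count, the ring size and the two defined stereocentres stay as they were, while a ring nitrogen replaces the oxygen and the group gains a hydrogen-bond donor, so even an exchange of this limited kind can cost much of the inhibition. Nothing given here accounts for the size of the step.

The compounds shown leave open whether the hydrogen on the new ring nitrogen matters, or the presence of that nitrogen itself, a question that a methyl or acetyl group on that nitrogen would address. They also leave open how the two ring methyl groups contribute on either ring, as the unsubstituted morpholine and piperazine would show, and whether the step holds on the other cores.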